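This account rests on a few compounds, and the source may have more. Where it says the series, first, only, none or still open, it means among the compounds named here.

Measured so far:
compound 1 `CS(=O)(=O)Nc1cccc2c1CCC2c1ncc[nH]1`; in a functional assay on CHO cells for agonist activity at Alpha-1D adrenergic receptor (Homo sapiens), read by FLIPR and calcium flux (on this read-out lower numbers stand for an effect already at smaller amounts and higher numbers for an effect only at larger amounts of compound), compound 1 gives > 10000 nM, which is a limit of the assay.
compound 2 `Cc1ccc2c(c1NS(C)(=O)=O)CCC2c1ncc[nH]1`; in this assay compound 2 gives > 10000 nM, also a limit of the assay.

Compound 1 stands only as a limit in this assay, at the limit of > 10000 nM in this assay, at which 2 of the 2 values shown sit, where every value of the series sits. Within the data shown here, the single measured step, a step that the two limits leave unreadable from compound 1 to compound 2, yields no size and no direction. Compound 3 `c1cc(-c2cn[nH]c2)c2c(c1)C(c1ncc[nH]1)CC2` differs from compound 1 by 1H-pyrazol-4-yl in place of methanesulfonamido on an aromatic carbon. Among the measured compounds shown here, no measured step bears on this exchange, since the step from compound 1 to compound 2 is unreadable and concerns a different group. The expectation for compound 3 is therefore guarded: a step of an at least 1.2-fold lower number from compound 1 to compound 3 (0.09 log units; that floor lies within the scatter) in this assay is estimated, with the reading most likely again a limit. Compound 3 is expected at 8000 nM, between 1000 nM and 30000 nM.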

Compound 3, half-maximal effective concentration: 319 nM
For compound 3 the middle estimate is 25-fold (1.40 log units) above the measured one; measured number below the stated range.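

Compound 1 and compound 2 both sit at one limit of the assay, and the step between them cannot be read, so neither showed whether this series can respond at all in this assay: the limit of > 10000 nM in this assay, at which 2 of the 3 values shown sit.

This aromatic carbon, ortho to a fused ring, now proves sensitive to what it carries, with 1H-pyrazol-4-yl in place of methanesulfonamido giving an at least 31-fold lower number from compound 1 to compound 3 (1.49 log units; beyond the scatter). The two groups have the same count of heavy atoms and of hydrogen-bond donors, but the entering group brings a five-membered aromatic ring, where the leaving group has no ring.

Open, going by these compounds, is how a phenyl or a simple amine at this carbon would read in this assay, which would help separate the ring from its nitrogens. Also open, on these data alone, is whether a methyl on the aromatic ring changes the reading on the background of compound 3.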